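A few compounds are considered here, and "the series" means these few. Any claim that something is new, unique, unknown or untested is made for them only; others in the source may bear on it.

Compound 1 `CC(C)(C)C/N=C(\NC#N)Nc1ccncc1` gives 5 mg/kg in a functional assay on the whole organism (blood, strain Wistar-Okamoto) with Rattus norvegicus as the target, with a stated time of 5 days; a higher number here means that more compound is needed for the effect, a lower number that less compound is needed. Compound 2 `CCC(C)(C)/N=C(\NC#N)Nc1ccncc1` gives 2.5 mg/kg in this assay.

For the measured compounds named here, compound 2 shows the lower of the two numbers, yet its only neighbour is compound 1, and the step of a 2.0-fold lower number from compound 1 to compound 2 (0.30 log units; within the scatter) stays within the scatter. Compound 3 `CC(C)C(C)(C)/N=C(\NC#N)Nc1ccncc1` differs from compound 2 by methyl in place of hydrogen on a saturated chain carbon bound to two saturated chain carbons. Going by the values given here, only that one measured step bears on the change, and it stayed within the scatter, so no step beyond the scatter is expected in this assay. The expected step is no change at the digits printed from compound 2 to compound 3 (within the scatter), none beyond the scatter. Compound 3 is therefore estimated at 2.5 mg/kg, with a range from 1.2 mg/kg to 5 mg/kg.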

Compound 3, minimum effective dose: 20 mg/kg
For compound 3 the middle estimate is 8.0-fold (0.90 log units) below the measured one; the whole stated range lies below it.
By their numbers in this assay, from the lowest: compounds 2 and 1 (each within the scatter of the next); then compound 3.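

For the compounds shown here, one added methyl on a saturated chain carbon bound to two saturated chain carbons gives an 8.0-fold higher number from compound 2 to compound 3 (0.90 log units; beyond the scatter) in this assay, the first change in this set that clearly exceeds the scatter. Replacing neopentyl with 1,1,2-trimethylpropyl also gives a 4.0-fold higher number from compound 1 to compound 3 (0.60 log units; beyond the scatter), so these branched groups on the double-bonded nitrogen are not interchangeable. No available evidence explains this rise. As far as these compounds go, whether a straight hexyl chain or a cyclohexyl ring on that nitrogen would bring the number back down remains open.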